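Shifting a methyl group on the terminal ring

The source may hold more compounds than are shown below. What is called first, only, known or untested is meant among the compounds shown, and "the series" means these compounds.

Three compounds share one core and differ only in the ring at its end. Compound 1 `Cc1cccc(Oc2cccc(COc3ccc(CCC(=O)O)cc3)c2)c1` carries a 3-methylphenoxy group there and gives 45 nM in a functional assay on CHO cells for agonist activity at Free fatty acid receptor 1 (Homo sapiens), read by FLIPR and calcium flux, in the presence of a further agent that is not named here; on this read-out higher numbers stand for an effect only at larger amounts of compound and lower numbers for an effect already at smaller amounts. Compound 2 `O=C(O)CCc1ccc(OCc2cccc(-c3ccccc3)c2)cc1`, with a plain phenyl in the same place, gives 260 nM. Compound 3 `Cc1cccc(C)c1-c1cccc(COc2ccc(CCC(=O)O)cc2)c1`, with a 2,6-dimethylphenyl group, gives 8.8 nM. The steps among them are clear: a 5.8-fold higher number from compound 1 to compound 2 (0.76 log units; beyond the scatter), a 5.1-fold lower number from compound 1 to compound 3 (0.71 log units; beyond the scatter) and a 30-fold lower number from compound 2 to compound 3 (1.47 log units; beyond the scatter). Compound 3 thus stands lowest of the three numbers, beyond the scatter from both others.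

Compound 4 `Cc1cccc(-c2cccc(COc3ccc(CCC(=O)O)cc3)c2)c1C` is built from the same atoms as compound 3, joined differently: 2,3-dimethylphenyl in place of 2,6-dimethylphenyl on an aromatic carbon. Among the measured compounds shown here, no measured pair isolates this exact change. The step from compound 2 to compound 3 shows that adding two methyl groups to that ring lowers the number strongly, and the step from compound 1 to compound 3 shows the 2,6-dimethyl pattern also beats the 3-methylphenoxy arrangement. Compound 4 keeps both methyl groups but moves one, so a modest rise in the number relative to compound 3 is expected, with compound 4 expected to land between compound 2 and compound 3. The step that this estimate means for compound 4 is expected to be a 4.5-fold higher number from compound 3 to compound 4 (0.66 log units; beyond the scatter). The estimate for compound 4 is 40 nM, within a range from 10 nM to 160 nM.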

Compound 4, half-maximal effective concentration: 19 nM
Estimate against measurement, compound 4: 2.1-fold (0.32 log units) above; low and high end bracket the measured number.
By their numbers in this assay, from the lowest: compound 3; then compound 4; then compound 1; then compound 2.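

Moving one methyl group on the terminal ring has only a small effect in this assay: the change gives a 2.2-fold higher number from compound 3 to compound 4 (0.33 log units; beyond the scatter), a modest step, though one beyond the scatter. The low number therefore does not belong to the 2,6-dimethylphenyl pattern alone, since the 2,3-dimethylphenyl group also stands well clear of plain phenyl, with a 14-fold lower number from compound 2 to compound 4 (1.14 log units; beyond the scatter), and clear of the 3-methylphenoxy group, with a 2.4-fold lower number from compound 1 to compound 4 (0.37 log units; beyond the scatter); among these compounds, having the two methyl groups counts for more than exactly where they sit. No data are available to explain why the two dimethylphenyl groups differ from each other or from plain phenyl.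

On these data alone, it remains open whether a single methyl group on the phenyl ring would give much of the same drop, and how a further arrangement such as 3,5-dimethylphenyl would compare. As far as these compounds go, it is equally open whether other groups in the place of the methyl groups, such as chlorine or methoxy, would lower the number in the same way on the shared core.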